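Compound 3 to compound 4: cyclohexyl for oxan-4-yl

The source may report more compounds than this note shows. Statements on the series, on what has been measured and on what is new or still open speak of the compounds shown alone.

In a functional assay on BT-474 cells (Homo sapiens) for inhibition, read by MTT assay, with a stated time of 5 days (a higher number here means a weaker inhibitor, a lower number a stronger inhibitor), compound 3 `Cc1cc(Nc2nc(NCc3ccc(F)cc3F)nc3c2cnn3C2CCOCC2)n[nH]1` gives 2350 nM, the lowest of the three numbers, against compound 1 `Cc1cc(Nc2nc(NCc3ccc(C#N)cc3)nc3[nH]ncc23)n[nH]1` at 12100 nM and compound 2 `Cc1cc(Nc2nc(NCc3ccc(Cl)cc3)nc3c2cnn3C2CCOCC2)n[nH]1` at 18300 nM. Compound 4 `Cc1cc(Nc2nc(NCc3ccc(F)cc3F)nc3c2cnn3C2CCCCC2)n[nH]1` carries cyclohexyl in place of oxan-4-yl on an aromatic nitrogen. Among the measured compounds shown here, the one measured step, a 7.8-fold lower number from compound 2 to compound 3 (0.89 log units; beyond the scatter), is a change of the halogenated phenyl group, not of the group on the aromatic nitrogen, and it gives no size for this swap. With no measured guide, no change beyond the scatter is expected in this assay, in either direction. The expected step is a 1.1-fold higher number from compound 3 to compound 4 (0.04 log units; within the scatter). For compound 4 the estimated value is 2600 nM, with an expected range of 900 nM to 7500 nM.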

Compound 4, half-maximal inhibitory concentration: 6230 nM
Beside the measured number, compound 4's estimate is 2.4-fold (0.38 log units) below it; the measured number falls inside the stated range.
By their numbers in this assay, from the lowest: compound 3; then compounds 4, 1 and 2 (each within the scatter of the next, the first and the last beyond it).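

In this assay, the group on the aromatic nitrogen affects the result: cyclohexyl in place of oxan-4-yl gives (a 2.7-fold higher number from compound 3 to compound 4 (0.42 log units; beyond the scatter)). This change replaces the ring oxygen with carbon, so the single hydrogen-bond acceptor of oxan-4-yl is lost while the count of heavy atoms stays the same. Nothing available explains the rise in the number. Still open, from the compounds shown here alone, is how piperidin-4-yl, with a ring amine, or a longer chain would compare with oxan-4-yl at this position. Going by these compounds, whether this step holds with 4-chlorophenyl in place of 2,4-difluorophenyl also remains open.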